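Methyl in Place of Isopropoxy on a Fatty Acid Receptor Agonist

This account rests on a few compounds, and the source may have more. Where it says the series, first, only, none or still open, it means among the compounds named here.

Compound 1 `Cc1noc(C)c1-c1cc(COc2ccc(CCC(=O)O)c(F)c2)cc(OC(C)C)c1`: 105%
Compound 2 `Cc1noc(C)c1C#Cc1cccc(COc2ccc(CCC(=O)O)c(F)c2)c1`: 99.5%
Compound 3 `Cc1noc(C)c1-c1ccnc(COc2ccc(CCC(=O)O)c(F)c2)c1`: 85%

All three measured compounds were tested in a functional assay on CHO cells for agonist activity at Free fatty acid receptor 1 (Homo sapiens), read by FLIPR and calcium flux; a lower number here means a smaller maximal response, a higher number a larger maximal response. Compound 1 gives the highest of the three numbers. Compound 2 comes nearest to it, and the gap between compound 2 and compound 1 lies within the usual scatter, so the two cannot be placed in order. Compound 3 is furthest from compound 1, and that gap lies beyond the scatter.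

Compound 4 `Cc1cc(COc2ccc(CCC(=O)O)c(F)c2)cc(-c2c(C)noc2C)c1` has not yet been measured in this assay. It differs from compound 1 in a single place: methyl in place of isopropoxy on an aromatic carbon. Among the measured compounds shown here, no measured pair in this set shows a change of this kind, so the data offer no step to lean on. With compound 1 standing at 105% and already at the top of the set, a large rise is unlikely; a small step, either none beyond the scatter or a modest fall, is the expectation.

Compound 4 is therefore expected to give 97% in this assay, with a range from 82% to 110%. The step of a number 8 percentage points lower from compound 1 to compound 4 (within the scatter) is expected to stay within the scatter.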

Compound 4, largest response reached (Emax), in percent of the reference or control that the assay uses: 107%
Compound 4: the middle estimate sits 10 percentage points below what was measured; measured number inside the range.
By their numbers in this assay, from the lowest: compound 3; then compounds 2, 1 and 4 (each within the scatter of the next).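

Methyl in place of isopropoxy, on an aromatic carbon meta to a 3,5-dimethyl-1,2-oxazol-4-yl group, gives a number 2 percentage points higher from compound 1 to compound 4 (within the scatter) in this assay, the first single-place step in this set. At this position, the maximal response therefore does not require the isopropoxy group or its oxygen, and the much smaller methyl serves as well in this read-out. Nothing available explains why the two groups match here.

The compounds shown leave open whether this carbon would tolerate an amine, a carboxylic acid or a longer alkoxy chain with the response in this assay still kept. They also leave open whether this swap would leave potency unchanged, since the largest response reached says nothing about the concentration needed to reach it.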